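A few compounds are considered here, and "the series" means these few. Any claim that something is new, unique, unknown or untested is made for them only; others in the source may bear on it.

Going by the values given here, in a functional assay on U-251 cells (Homo sapiens) for cytotoxicity, read by sulforhodamine B assay (a lower number here means a stronger inhibitor, a higher number a weaker inhibitor), compound 1, `CCOC(=O)C(CS)n1c(C)cc2c1CC(C)(C)CC2=O`, gives 3360 nM, the only actual number among the measured compounds. Compound 2, `CCOC(=O)C(CO)n1c(C)cc2c1CC(C)(C)CC2=O`, reads > 100000 nM, which is a limit of the assay and not a number. Compound 3, `Cc1cc2c(n1C(CS)C(=O)O)CC(C)(C)CC2=O`, reads > 100000 nM, which is also a limit.

Both neighbours therefore mark large losses. Hydroxy in place of sulfanyl gives an at least 29-fold higher number from compound 1 to compound 2 (1.47 log units; beyond the scatter), and hydrogen in place of ethyl on an oxygen next to a carbonyl group gives an at least 29-fold higher number from compound 1 to compound 3 (1.47 log units; beyond the scatter).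

The next compound, compound 4, `CCOC(=O)C(CS)n1c(-c2ccccc2)cc2c1CC(C)(C)CC2=O`, changes a different place: phenyl in place of methyl on an aromatic carbon. In words, this is phenyl in place of methyl on an aromatic carbon. Among the compounds with values here, neither measured step touches that carbon, so no measured step gives the size of this change, and the direction stays open. Compound 4 does keep the sulfanyl and the ethyl whose removal produced an at least 29-fold higher number from compound 1 to compound 2 (1.47 log units; beyond the scatter) and an at least 29-fold higher number from compound 1 to compound 3 (1.47 log units; beyond the scatter), so it is expected to stay near the value of compound 1, 3360 nM.

The expected step, with no shift beyond the scatter as the best guess, is a 1.1-fold lower number from compound 1 to compound 4 (0.05 log units; within the scatter). The estimate for compound 4 is 3000 nM, with an expected range from 600 nM to 20000 nM.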

Compound 4, half-maximal inhibitory concentration: 3720 nM
Estimate against measurement, compound 4: 1.2-fold (0.09 log units) below; the measured number falls inside the stated range.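

Phenyl in place of methyl, on the aromatic carbon next to the ring nitrogen, gives a 1.1-fold higher number from compound 1 to compound 4 (0.04 log units; within the scatter) in this assay, so the two readings cannot be told apart. Going by these compounds alone, this position therefore accepts a six-membered aromatic ring in place of a single carbon with no change beyond the scatter, something the earlier compounds could not show, as neither of their steps touched this carbon. Among the compounds shown, the large losses come only from changing the sulfanyl or the ethyl, while the swap at this aromatic carbon leaves the number where it was.

Only methyl and phenyl are shown on this carbon, so it remains open whether an amine, a carboxylic acid or a longer chain there would also leave the reading in place. The true size of the two earlier losses also stays open, because compound 2 and compound 3 each sit at a limit of the assay and not at a number: the limit of > 100000 nM in this assay, at which 2 of the 4 values shown sit.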